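The source may report more compounds than this note shows. Statements on the series, on what has been measured and on what is new or still open speak of the compounds shown alone.

Three compounds share one core and differ only in the groups attached to it. Compound 1 `CC(=O)Nc1nc2ccccn2c1-c1ccc(O)cc1` carries an acetyl on a ring nitrogen; in an assay on isolated protein for inhibition of ubiquitin carboxyl-terminal hydrolase 47 (Homo sapiens) (a higher number here means a weaker inhibitor, a lower number a stronger inhibitor), compound 1 gives > 100000 nM, which is a limit of the assay and not a number. Compound 2 `CNc1nc2ccccn2c1-c1ccc(O)cc1` has a methyl in that place, and in this assay compound 2 gives > 100000 nM, again a limit. The step that the two limits leave unreadable from compound 1 to compound 2 can therefore not be read. Compound 3 `Nc1nc2cc(C(F)(F)F)ccn2c1-c1ccc(O)cc1` carries a free amino group and a trifluoromethyl on the fused ring; in this assay compound 3 gives > 100000 nM, also a limit. Compound 3 thus stands at the limit of > 100000 nM in this assay, at which 3 of the 3 values shown sit, and no value shown here is a number.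

Compound 4 `Nc1nc2cc(C3CCNCC3)ccn2c1-c1ccc(O)cc1` differs from compound 3 in one place: piperidin-4-yl in place of trifluoromethyl on an aromatic carbon. No measured step bears on this change, since the only step shown could not be read and both of its compounds sat at the limit. The expectation for compound 4 therefore rests on the three limits alone: compound 4 is estimated at 100000 nM, within 20000 nM to 500000 nM. The step of a number no higher from compound 3 to compound 4 (the limit leaves the size open) is expected to stay within the scatter, most likely as another limit.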

Compound 4, half-maximal inhibitory concentration: > 100000 nM
Compound 4 gave a limit, no number; the forecaster's own chance of this, stated with the estimate: 75%; the middle value sits exactly at the limit.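

In this assay compound 4 gives > 100000 nM, which is a limit of the assay and not a number. Compound 3 also sits at a limit, and the change from compound 3 to compound 4 cannot be read as a step. The compounds shown leave open whether any group on the shared core gives a true number in this assay: the limit of > 100000 nM in this assay, at which 4 of the 4 values shown sit.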